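Swapping the aromatic ring on the amine nitrogen

The compounds below may be only part of what the source reports. "The series", "measured", "known", "first", "only" and "open" are said of these compounds alone.

In a functional assay (aorta) with Rattus norvegicus as the target (a lower number here means a stronger inhibitor, a higher number a weaker inhibitor), compound 1 `CCO/C(O)=C1\C(COCCNc2noc(N)n2)=NC(C)=C(C(=O)OC)C1c1cccc(Cl)c1Cl` gives 3.16 nM, compound 2 `CCO/C(O)=C1\C(COCC/N=C(/N)S)=NC(C)=C(C(=O)OC)C1c1cccc(Cl)c1Cl` gives 1 nM and compound 3 `CCO/C(O)=C1\C(COCCNc2nccc(O)n2)=NC(C)=C(C(=O)OC)C1c1cccc(Cl)c1Cl` gives 2.51 nM. Compound 3 therefore sits level with compound 1 and clear of the lowest number in the set, that of compound 2, as a 2.5-fold higher number from compound 2 to compound 3 (0.40 log units; beyond the scatter) shows.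

The open step leads to compound 4 `CCO/C(O)=C1\C(COCCNc2n[s+]([O-])nc2OC)=NC(C)=C(C(=O)OC)C1c1cccc(Cl)c1Cl`, which has not yet been measured. The change is a group of 8 heavy atoms (3 carbon, 2 nitrogen, 2 oxygen, 1 sulfur; one five-membered aromatic ring with 3 hetero atoms) in place of a group of 7 heavy atoms (4 carbon, 2 nitrogen, 1 oxygen; one six-membered aromatic ring with 2 hetero atoms), on an amine nitrogen: 4-hydroxypyrimidin-2-yl leaves and a group with no common name enters, on an amine nitrogen.

Among the compounds with values here, the closest precedent is the one exchange of an aromatic ring for another aromatic ring at this place, a 1.3-fold lower number from compound 1 to compound 3 (0.10 log units; within the scatter), which stays within the scatter. The larger, modest steps, a 3.2-fold lower number from compound 1 to compound 2 (0.50 log units; beyond the scatter) and the step to compound 3 noted above, both involve the ringless group of compound 2, so they bear on this change less directly. Within the data shown here, compound 4 keeps an aromatic ring, but its entering group has no measured precedent. No step beyond the scatter is therefore expected in this assay, and no direction is favoured with confidence. The expected step is a 1.2-fold higher number from compound 3 to compound 4 (0.08 log units; within the scatter). For compound 4 the estimated value is 3 nM, with an expected range of 0.8 nM to 12 nM.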

Compound 4, half-maximal inhibitory concentration: 10 nM
Compound 4: middle estimate off by 3.3-fold (0.52 log units), on the low side, within the range that was stated.
By their numbers in this assay, from the lowest: compound 2; then compounds 3 and 1 (each within the scatter of the next); then compound 4.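

In this assay, exchanging one aromatic ring for another on the amine nitrogen now has a visible cost: the new group gives a 4.0-fold higher number from compound 3 to compound 4 (0.60 log units; beyond the scatter), whereas the earlier ring exchange gave only a 1.3-fold lower number from compound 1 to compound 3 (0.10 log units; within the scatter). Sharing one five-membered aromatic ring with 3 hetero atoms does not make two groups equivalent at this position, as the exchange of one such ring for the other gives a 3.2-fold higher number from compound 1 to compound 4 (0.50 log units; beyond the scatter). The ringless group sets the wider limit of the series, with a 10-fold higher number from compound 2 to compound 4 (1.00 log units; beyond the scatter), and compound 4 now has the highest number of the set, with its steps to all three other compounds printed as beyond the scatter.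

The data shown offer no measurement that accounts for these steps, so the loss remains an observation without an explanation. Still open, going by these compounds, is which part of the entering group carries the loss, and whether a hydroxyl or an amine in place of the methoxy on the ring of compound 4, or a plain phenyl ring on the amine nitrogen, would return the number towards that of compound 3.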